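The source may report more compounds than this note shows. Statements on the series, on what has been measured and on what is new or still open speak of the compounds shown alone.

Of the compounds shown here, three have been measured in a functional assay on SMMC-7721 cells (Homo sapiens) for cytotoxicity, read by MTT assay, with a stated time of 4 days; on this read-out higher numbers stand for weaker inhibition and lower numbers for stronger inhibition. Compound 1 `C=C1C(=O)[C@]23C[C@@]1(O)CC[C@H]2c1ccc(OS(=O)(=O)c2ccc(C)cc2)c(C)c1[C@@H]3Cn1cc(-c2ccc(Br)cc2)nn1` gives 4320 nM. Compound 2 `C=C1C(=O)[C@]23C[C@@]1(O)CC[C@H]2c1ccc(O)c(C)c1[C@@H]3Cn1cc(-c2ccccn2)nn1` gives 1270 nM. Compound 3 `C=C1C(=O)[C@]23C[C@@]1(O)CC[C@H]2c1ccc(O)c(C)c1[C@@H]3Cn1cc(-c2ccc(C(F)(F)F)cc2)nn1` gives 1440 nM, a number close to that of compound 2 and clearly lower than that of compound 1, which places compound 3 second highest of the three. For the measured compounds named here, the one single-point change measured so far is the swap of the aryl group on the triazole, and it gave a 1.1-fold higher number from compound 2 to compound 3 (0.05 log units; within the scatter), so that exchange of one aryl group for another left the read-out essentially unchanged.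

Compound 4 `C=C1C(=O)[C@]23C[C@@]1(O)CC[C@H]2c1ccc(O)c(C)c1[C@@H]3Cn1cc(-c2ccc(Br)cc2)nn1` is the next compound. Starting from compound 3, the change is bromo in place of trifluoromethyl on an aromatic carbon. This is again an exchange at the outer aryl group on the triazole, the same kind of change that produced a 1.1-fold higher number from compound 2 to compound 3 (0.05 log units; within the scatter). On that basis the step from compound 3 to compound 4 is expected to be small, a 1.0-fold higher number from compound 3 to compound 4 (0.02 log units; within the scatter), with no direction beyond the scatter. For compound 4 the estimate in this assay is 1500 nM, with a range from 700 nM to 3200 nM.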

Compound 4, half-maximal inhibitory concentration: 1300 nM
For compound 4 the middle estimate is 1.2-fold (0.06 log units) above the measured one; measured number inside the range.
By their numbers in this assay, from the lowest: compounds 2, 4 and 3 (each within the scatter of the next); then compound 1.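

In this assay, bromo and trifluoromethyl on the outer phenyl ring cannot be told apart, a 1.1-fold lower number from compound 3 to compound 4 (0.04 log units; within the scatter), and neither can 4-bromophenyl and pyridin-2-yl, a 1.0-fold higher number from compound 2 to compound 4 (0.01 log units; within the scatter), so all three aryl groups on the triazole lie within the scatter of one another. For the compounds shown here, the oxygen on the aromatic ring gives the only single change here that goes beyond the scatter: with hydrogen in place of (4-methylphenyl)sulfonyl, the step is a 3.3-fold lower number from compound 1 to compound 4 (0.52 log units; beyond the scatter). Nothing available bears on why these results came out as they did.

From the compounds shown here alone, the sulfonyl result rests on a single pair, so it remains open how a smaller group on that oxygen, such as methyl or acetyl, would read. Going by these compounds, it also remains open whether an amine or a carboxylic acid in place of the aryl group on the triazole would shift the number.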